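This account rests on a few compounds, and the source may have more. Where it says the series, first, only, none or still open, it means among the compounds named here.

Compound 3 `O=c1cc(-c2ccccc2)oc2cc(O)c(OCCCCN3CCCC3)c(O)c12` is the weakest inhibitor of the three measured: in a functional assay on BCG823 cells (Homo sapiens) for antiproliferative activity, read by MTT assay, with a stated time of 48 h (a lower number here means a stronger inhibitor, a higher number a weaker inhibitor), compound 3 gives 86400 nM, the highest number of the set. Compound 1 `CN1CCN(CCCCOc2c(O)cc3oc(-c4ccccc4)cc(=O)c3c2O)CC1` gives 82900 nM, and a 1.0-fold higher number from compound 1 to compound 3 (0.02 log units; within the scatter). Compound 2 `O=c1cc(-c2ccccc2)oc2cc(OCc3ccccc3)c(OCCCCN3CCCCC3)c(O)c12` gives 3000 nM, far below both. The step to compound 4 `O=c1cc(-c2ccccc2)oc2cc(OCc3ccccc3)c(OCCCCN3CCCC3)c(O)c12` is benzyl in place of hydrogen on an oxygen on an aromatic ring. Among the measured compounds shown here, no measured pair isolates this change: compound 2 carries the benzyl group but also a different amine ring, so its gap to compound 3 mixes two changes, while the amine-ring swap alone, seen from compound 1 to compound 3, hardly moved the number. The benzyl group therefore seems to carry most of that gap, and a step of a 25-fold lower number from compound 3 to compound 4 (1.39 log units; beyond the scatter) is expected. For compound 4 the estimate is 3500 nM, ranging from 1000 nM to 12000 nM.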

Compound 4, half-maximal inhibitory concentration: 3200 nM
Beside the measured number, compound 4's estimate is 1.1-fold (0.04 log units) above it, and the stated range covers the measured number.
By their numbers in this assay, from the lowest: compounds 2 and 4 (each within the scatter of the next); then compounds 1 and 3 (each within the scatter of the next).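

Replacing hydrogen with benzyl on this aromatic oxygen, hydroxy to benzyloxy, can now be read as a single change, and it is a large one (a 27-fold lower number from compound 3 to compound 4 (1.43 log units; beyond the scatter)). With benzyl in place, swapping the amine ring still changes little (a 1.1-fold higher number from compound 2 to compound 4 (0.03 log units; within the scatter)), so in both hydroxy and benzyloxy pairs the number follows the oxygen substituent rather than the ring. Open, on these data alone, is whether a methyl group on this oxygen would match benzyl, and whether a shorter chain or a dimethylamino group would change the number. Nothing given here explains the effect of benzyl.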